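A few compounds are considered here, and "the series" means these few. Any claim that something is new, unique, unknown or untested is made for them only; others in the source may bear on it.

Measured compounds:
compound 1 `CCCCCCCCCCCCNC(=O)[C@@H](NC(=O)c1ccco1)[C@@H](C)O` — 67500 nM
compound 2 `CCCCCCCCCCCCNC(=O)[C@@H](NC(=O)c1nccc2ccccc12)[C@@H](C)O` — 50500 nM
compound 3 `CCCCCCCCCCCCNC(=O)[C@@H](NC(=O)/C=C/c1ccccc1)[C@@H](C)O` — > 200000 nM

In a functional assay on MCF7 cells (Homo sapiens) for cytotoxicity, read by MTT assay, with a stated time of 48 h (a lower number here means a stronger inhibitor, a higher number a weaker inhibitor), compound 3 reports only a limit, > 200000 nM, and no number. Compound 1 gives 67500 nM and compound 2 gives 50500 nM in this assay; the pair sits within the scatter of each other, a 1.3-fold lower number from compound 1 to compound 2 (0.13 log units; within the scatter). Compound 3 stands at the weak end of the three: an at least 2.9-fold higher number from compound 1 to compound 3 (0.47 log units; beyond the scatter) and an at least 3.9-fold higher number from compound 2 to compound 3 (0.59 log units; beyond the scatter), and in each case the endpoint is the limit (the limit of > 200000 nM in this assay, at which 1 of the 3 values shown sits).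

Compound 4 `CCCCCCCCCCCCNC(=O)[C@@H](NS(=O)(=O)c1ccc(C)cc1)[C@@H](C)O` differs from compound 3 in one place: (4-methylphenyl)sulfonyl in place of (2-phenylethenyl)carbonyl on an amine nitrogen. Among the compounds with values here, no measured step exchanges a carbonyl for a sulfonyl on this nitrogen, so the measured steps bear on it only indirectly: they show that the (2-phenylethenyl)carbonyl of compound 3 carries the weakest number and that the aroyl groups of compounds 1 and 2 sit some way lower. Compound 4 is therefore expected to return a number somewhere near compounds 1 and 2 rather than at the limit, an expected step of an at least 2.0-fold lower number from compound 3 to compound 4 (0.30 log units; that floor lies within the scatter). The estimate for compound 4 is 100000 nM, with a range from 40000 nM to 300000 nM.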

Compound 4, half-maximal inhibitory concentration: 31100 nM
Compound 4: the middle estimate sits 3.2-fold (0.51 log units) above what was measured; the whole stated range lies above it.
By their numbers in this assay, from the lowest: compounds 4, 2 and 1 (each within the scatter of the next, the first and the last beyond it). At a limit, above all of these: compound 3.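

Within the data shown here, on the amine nitrogen, a sulfonyl now stands where the earlier compounds carried a carbonyl, and in this assay the series keeps a measured number with it: an at least 6.4-fold lower number from compound 3 to compound 4 (0.80 log units; beyond the scatter). That step is only a floor, with a limit and no number at the compound 3 end: the limit of > 200000 nM in this assay, at which 1 of the 4 values shown sits. The (4-methylphenyl)sulfonyl also separates modestly from the (furan-2-yl)carbonyl, a 2.2-fold lower number from compound 1 to compound 4 (0.34 log units; beyond the scatter), yet compound 4 stays within the scatter of compound 2, so the exchange does not set it apart from the isoquinolin-1-yl carbonyl.

Going by these compounds, whether the step belongs to the sulfonyl or to the 4-methylphenyl stays open; a 4-methylbenzoyl or a methanesulfonyl group on this nitrogen would separate the two. Also open, on these data alone, is how the sulfonyl fares with a shorter chain on the amide nitrogen.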